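Swapping the Acyl Group on a Cytotoxicity-Tested Quinolinone

A few compounds are considered here, and "the series" means these few. Any claim that something is new, unique, unknown or untested is made for them only; others in the source may bear on it.

Measured compounds:
Compound 1, `O=c1[nH]c2ccc(Cl)cc2c(-c2ccccc2Cl)c1CCO`, 380000 nM in an ADME assay on HepG2 2.2.15 cells (Homo sapiens) for cytotoxicity; on this read-out lower numbers stand for higher toxicity in this test and higher numbers for lower toxicity in this test
Compound 2, `O=C(OCCc1c(-c2ccccc2Cl)c2cc(Cl)ccc2[nH]c1=O)c1ccco1`, 98000 nM in this assay

Going by the values given here, compound 2 stands at the lowest of the two numbers in this assay, with compound 1 as its only neighbour, at a higher number beyond the scatter. Among the compounds with values here, the one measured step, a 3.9-fold lower number from compound 1 to compound 2 (0.59 log units; beyond the scatter), came from attaching a (furan-2-yl)carbonyl in place of hydrogen on an oxygen on a saturated carbon of the shared core.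

Compound 3, `O=C(/C=C/c1cccnc1)OCCc1c(-c2ccccc2Cl)c2cc(Cl)ccc2[nH]c1=O`, has not yet been measured in this assay. It differs from compound 2 in one place: 2-(pyridin-3-yl)ethenyl in place of furan-2-yl on a carbonyl carbon. Within the data shown here, no measured step exchanges one group on that carbonyl carbon for another, so the single known step does not bear on this change directly; it only shows that adding a group at this position shifted the number modestly. With no guide for the swap itself, no step beyond the scatter is expected in this assay. Compound 3 is therefore estimated at 85000 nM, within 30000 nM to 250000 nM, meaning an expected step of a 1.2-fold lower number from compound 2 to compound 3 (0.06 log units; within the scatter).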

Compound 3, half-maximal cytotoxic concentration: 39000 nM
Compound 3: middle estimate off by 2.2-fold (0.34 log units), on the high side; the measured number falls inside the stated range.
By their numbers in this assay, from the lowest: compound 3; then compound 2; then compound 1.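

In this assay, the group on the carbonyl carbon is not a silent part of the molecule: exchanging furan-2-yl for 2-(pyridin-3-yl)ethenyl gives a 2.5-fold lower number from compound 2 to compound 3 (0.40 log units; beyond the scatter), so one acyl group cannot simply stand in for another here, and the lower number points to higher toxicity in this test. Both acyl groups shown move the number in the same direction from the free alcohol, with a 3.9-fold lower number from compound 1 to compound 2 (0.59 log units; beyond the scatter) for (furan-2-yl)carbonyl and the larger 9.7-fold lower number from compound 1 to compound 3 (0.99 log units; beyond the scatter) for (2-(pyridin-3-yl)ethenyl)carbonyl, and no compound shown goes against this. Nothing measured here explains why the entering group gives the lower number.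

The compounds shown leave open which feature of 2-(pyridin-3-yl)ethenyl carries the step, as its six-membered aromatic ring with one nitrogen, its double bond and its greater number of heavy atoms all enter together. A phenyl ring in place of the pyridin-3-yl ring, or a saturated ethyl link in place of the ethenyl link, would separate these features, and a small acetyl group would show how far the number moves with a much simpler acyl group.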